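A few compounds are considered here, and "the series" means these few. Any claim that something is new, unique, unknown or untested is made for them only; others in the source may bear on it.

Measured compounds:
- compound 1, `Cc1ccnc(/C(N)=N/NC(=S)N2CCCC2)c1`: 87.9%
- compound 2, `N/C(=N\NC(=S)N1CCOCC1)c1ccc(F)cn1`: 85.9%
- compound 3, `N/C(=N\NC(=S)N1CCOCC1)c1ccccn1`: 15%

All three were tested in a functional assay on A-375 cells (Homo sapiens) for cytotoxicity, read by MTT assay, with a stated time of 72 h, tested at 30 uM; on this read-out lower numbers stand for less inhibition of growth and higher numbers for more inhibition of growth at the one concentration tested. Compound 3 stands lowest of the three numbers; its nearest neighbour is compound 2, whose value lies well beyond the scatter above it, and compound 1 lies further still. For the measured compounds named here, the one single-point step among them is a number 70.9 percentage points lower from compound 2 to compound 3 (beyond the scatter), a large drop when a fluoro on the aromatic ring gives way to hydrogen.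

The unmeasured compound 4, `Cc1ccnc(/C(N)=N/NC(=S)N2CCOCC2)c1`, differs from compound 3 by methyl in place of hydrogen on an aromatic carbon. This is not the same change as removing fluoro, so the step from compound 2 to compound 3 bears on it only loosely: it shows that the bare ring of compound 3 gives a low number while a substituted ring gives a high one. Compound 1, which also carries a methyl on that ring but differs from compound 3 in more than one place, gives a high value too. A large rise in this assay is therefore expected for compound 4, a number 55 percentage points higher from compound 3 to compound 4 (beyond the scatter), with considerable uncertainty. Compound 4 is estimated at 70%, between 30% and 95%.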

Compound 4, percent growth inhibition at one concentration: 87.4%
Compound 4: middle estimate off by 17.4 percentage points, on the low side; the range from low to high includes it.
By their numbers in this assay, from the lowest: compound 3; then compounds 2, 4 and 1 (each within the scatter of the next).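

In this assay, the methyl alone, placed on an aromatic carbon opposite the ring nitrogen, separates a low number from a high one, with a number 72.4 percentage points higher from compound 3 to compound 4 (beyond the scatter) as the only difference between the two structures. For the compounds shown here, the earlier step concerned the loss of a fluoro group, so this is the first direct reading of what a methyl does at this position. With that methyl in place, the group on the thiocarbonyl carbon can be morpholin-4-yl or pyrrolidin-1-yl, and a number 0.5 percentage points lower from compound 1 to compound 4 (within the scatter) means that these two compounds cannot be told apart; nothing available gives a cause for either result.

The compounds shown carry only hydrogen or methyl at this position, so it remains open whether an ethyl group, a methoxy group or a chlorine atom there would also give a high number. Going by these compounds, it is also open whether a pyrrolidin-1-yl compound with hydrogen at this position would give a number as low as the morpholin-4-yl one does, and so whether the effect of the methyl holds beyond this single pair.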